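This account rests on a few compounds, and the source may have more. Where it says the series, first, only, none or still open, it means among the compounds named here.

Three compounds of a shared core have been run in a functional assay on HEK293 cells for antagonist activity at Voltage-dependent L-type calcium channel subunit alpha-1C (Oryctolagus cuniculus), read by FLIPR; a lower number here means a stronger inhibitor, a higher number a weaker inhibitor. Compound 2 `C=C(C)CCOC(=O)C1=C(C)NC(C)=C(C(=O)OC)C1c1cccc([N+](=O)[O-])c1` gives 23 nM, the lowest number of the three. Compound 3 `CCCCCOC(=O)C1=C(C)NC(C)=C(C(=O)OCC)C1c1cccc([N+](=O)[O-])c1` gives 49 nM, a gap beyond the scatter, and compound 1 `CCOC(=O)C1=C(C)NC(COC(=O)c2ccccc2)=C(C(=O)OCC)C1c1cccc([N+](=O)[O-])c1` gives 210 nM, further away still. Compound 4 `COC(=O)C1=C(C)NC(C)=C(C(=O)OCCCOc2ccccc2)C1c1cccc([N+](=O)[O-])c1` differs from compound 2 in one place: phenoxymethyl in place of 1-methylethenyl on a saturated chain carbon, two bonds along the chain from an oxygen next to a carbonyl group. Going by the values given here, no measured pair shows this change, so the expectation rests on the spread already seen, where compound 3 at 49 nM sits nearer compound 2 than compound 1 at 210 nM does. The expected step of a 1.4-fold higher number from compound 2 to compound 4 (0.14 log units; within the scatter) is therefore small, toward a higher number if it clears the scatter at all. Compound 4 is estimated at 32 nM, between 9 nM and 120 nM.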

Compound 4, half-maximal inhibitory concentration: 9 nM
Compound 4: the middle estimate sits 3.6-fold (0.55 log units) above what was measured, and the stated range covers the measured number.
By their numbers in this assay, from the lowest: compound 4; then compound 2; then compound 3; then compound 1.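

In this assay the change to phenoxymethyl from 1-methylethenyl at this place on the chain gives a 2.6-fold lower number from compound 2 to compound 4 (0.41 log units; beyond the scatter) and so moves the number down, a modest step beyond the scatter. This place therefore accepts a larger group, with one six-membered aromatic ring of carbon only, without any loss in this assay. No measured evidence here accounts for the step. This single pair cannot separate the part played by the added oxygen from that of the ring. From the compounds shown here alone, what an amine, a carboxylic acid or a longer chain would do at this place stays open.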